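The source may hold more compounds than are shown below. What is called first, only, known or untested is meant among the compounds shown, and "the series" means these compounds.

Three compounds built on a shared core have been examined in an ADME assay on HeLa cells (Homo sapiens) for cytotoxicity, read by microscopy; on this read-out lower numbers stand for higher toxicity in this test and higher numbers for lower toxicity in this test. Compound 1 `CSc1nc(NCCCNc2ccnc3cc(Cl)ccc23)c(C#N)c(-c2ccccc2)n1` gives 100000 nM in this assay. Compound 2 `CSc1nc(NCCCCNc2ccnc3cc(Cl)ccc23)c(C#N)c(-c2cccc([N+](=O)[O-])c2)n1` gives 100000 nM in this assay, level with compound 1 at the digits shown; compound 1 is its nearest neighbour, with no change within the scatter. Compound 3 `CSc1nc(-c2ccc([N+](=O)[O-])cc2)c(C#N)c(N2CCN(c3ccnc4cc(Cl)ccc34)CC2)n1` gives > 100000 nM in this assay, and this is a limit of the measurement rather than a number. Among the values shown, one sits at this limit (the limit of > 100000 nM in this assay, at which 1 of the 3 values shown sits). All three compounds thus stand at the upper end of the scale, where toxicity in this test is low.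

Compound 4 `COc1ccc(-c2nc(SC)nc(NCCCCNc3ccnc4cc(Cl)ccc34)c2C#N)cc1` has not yet been measured in this assay. It differs from compound 2 in one place: 4-methoxyphenyl in place of 3-nitrophenyl on an aromatic carbon. The replacement puts 4-methoxyphenyl where 3-nitrophenyl stood, on an aromatic carbon of the shared core. Among the compounds with values here, no step between two measured compounds exists to gauge this change. Compound 1, compound 2 and compound 3 all sit at the same high end of the scale, so the expectation for this change is none beyond the scatter. The step of no change at the digits printed from compound 2 to compound 4 (within the scatter) is therefore estimated to be flat. Compound 4 is expected to give 100000 nM in this assay, with a range from 50000 nM to 200000 nM.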

Compound 4, minimum cytotoxic concentration: 20000 nM
Compound 4: middle estimate off by 5.0-fold (0.70 log units), on the high side, and the stated range ends above it.
By their numbers in this assay, from the lowest: compound 4; then compounds 1 and 2 (each within the scatter of the next).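

In this assay, within the data shown here, putting 4-methoxyphenyl where 3-nitrophenyl stood gives a 5.0-fold lower number from compound 2 to compound 4 (0.70 log units; beyond the scatter), the only step in this set that can be read, and a lower number here stands for higher toxicity in this test. The earlier compounds shown here could not show this: they differ from one another in more than one place, and their values all sit at the high end of the scale, so nothing yet showed that the group on this aromatic carbon, next to the ring nitrogen and ortho to a cyano group, could move the read-out at all. What lies behind the shift is not explained by anything measured in this set.

On these data alone, the swap replaces the group on the phenyl ring and also moves it to another place on that ring, so it remains open which of these two changes counts. Also open, as far as these compounds go, is how an aminophenyl group, or a phenyl ring carrying a carboxylic acid, would read on this same aromatic carbon, and whether the step would hold with a longer chain.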